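Fluorine in Place of Methyl on the 4-Methylphenyl Group

A few compounds are considered here, and "the series" means these few. Any claim that something is new, unique, unknown or untested is made for them only; others in the source may bear on it.

Of the compounds shown here, three sharing one core have been tested in a functional assay on PC-3 cells (Homo sapiens) for cytotoxicity, read by MTT assay, with a stated time of 72 h; a higher number here means a weaker inhibitor, a lower number a stronger inhibitor. Compound 1 `Cc1ccc(-c2ccc(C(=O)Nc3ccc(Oc4ccnc5[nH]ccc45)cc3)nc2)cc1` gives only a limit of the assay, > 10000 nM, rather than a number. Compound 2 `O=C(Nc1ccc(Oc2ccnc3[nH]ccc23)cc1)c1cc(-c2ccc(C(F)(F)F)cc2)ccn1` gives 14200 nM. Compound 3 `Cc1ccc(-c2ccc(C(=O)Nc3ccc(Oc4ccnc5[nH]ccc45)c(F)c3)nc2)cc1` gives 2640 nM, the lowest of the two numbers measured, and the nearest number, that of compound 2, is clearly higher. Among the measured compounds shown here, the single one-place step measured is an at least 3.7-fold lower number from compound 1 to compound 3 (0.57 log units; beyond the scatter). Its starting point is a limit, (the limit of > 10000 nM in this assay, at which 1 of the 3 values shown sits), so the true size of that step is only a floor.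

Compound 4 `O=C(Nc1ccc(Oc2ccnc3[nH]ccc23)c(F)c1)c1ccc(-c2ccc(F)cc2)cn1` keeps the fluorine of compound 3 and alters the 4-methylphenyl group: fluoro in place of methyl on an aromatic carbon. For the measured compounds named here, no measured step covers a methyl-to-fluoro swap at that place, so the only guide is compound 3 itself with its 2640 nM. An expected step of a 1.1-fold higher number from compound 3 to compound 4 (0.06 log units; within the scatter) in this assay would stay within the usual scatter. Compound 4 is therefore estimated to give 3000 nM, within a range from 1200 nM to 8000 nM.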

Compound 4, half-maximal inhibitory concentration: 13400 nM
For compound 4 the middle estimate is 4.5-fold (0.65 log units) below the measured one; the measured number lies above the stated range.
By their numbers in this assay, from the lowest: compound 3; then compounds 4 and 2 (each within the scatter of the next).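

Among the compounds shown here, this step is the first measured change on the outer ring, and it shows that this position is not indifferent in this assay: replacing methyl with fluoro gives a 5.1-fold higher number from compound 3 to compound 4 (0.71 log units; beyond the scatter). The swap exchanges one heavy atom for one heavy atom, adds no ring and leaves the hydrogen-bond donor and acceptor counts at zero, so even a very small change at this place can move the number beyond the scatter. Nothing measured here explains why the number rises, and no available data on a property of these groups bears on the step.

On these data alone, only methyl and fluoro are compared at this place, so it remains open how an ethyl chain, a methoxy group or an amine would behave there. Also open, as far as these compounds go, is whether the same swap would give a similar step on the core of compound 1, which lacks the added fluorine.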